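The source may hold more compounds than are shown below. What is called first, only, known or untested is meant among the compounds shown, and "the series" means these compounds.

Compound 1 `CC(C)(C)OC(=O)N(Cc1ccco1)C(=O)c1ccc(CN2Cc3ccccc3S2(=O)=O)cc1` gives 10600 nM in a functional assay on RAW264.7 cells (Mus musculus) for inhibition (on this read-out lower numbers stand for stronger inhibition and higher numbers for weaker inhibition), the lowest of the two numbers in hand. Compound 2 `O=C(NCc1ccco1)c1ccc(CN2Cc3ccccc3S2(=O)=O)cc1` gives 68400 nM, and the step of a 6.5-fold higher number from compound 1 to compound 2 (0.81 log units; beyond the scatter) comes from the tert-butoxycarbonyl alone. Compound 3 `O=C(c1ccc(CN2C(=O)c3ccccc3C2=O)cc1)N1CCCCC1` gives only a limit of the assay, > 100000 nM, and sits at the limit of > 100000 nM in this assay, at which 1 of the 3 values shown sits. Compound 4 `CC(C)(C)OC(=O)N(Cc1ccco1)C(=O)c1ccc(Cn2oc3ccccc3c2=O)cc1` differs from compound 1 by a group of 10 heavy atoms (7 carbon, 1 nitrogen, 2 oxygen; one five-membered aromatic ring with 2 hetero atoms, one six-membered aromatic ring of carbon only) in place of a group of 11 heavy atoms (7 carbon, 1 nitrogen, 2 oxygen, 1 sulfur; one five-membered non-aromatic ring with 2 hetero atoms, one six-membered aromatic ring of carbon only), on a saturated chain carbon bound to an aromatic carbon. Among the compounds with values here, no measured step touches this part of the core; the only step known concerns the tert-butoxycarbonyl, and compound 3 differs from compound 1 in two places at once. The change is therefore estimated with wide uncertainty: compound 4 is expected to land at 30000 nM, between 8000 nM and 100000 nM, a step of a 2.8-fold higher number from compound 1 to compound 4 (0.45 log units; beyond the scatter) toward weaker inhibition.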

Compound 4, half-maximal inhibitory concentration: 6690 nM
The estimate for compound 4 lay 4.5-fold (0.65 log units) above the measured number, outside the stated range (below it).
By their numbers in this assay, from the lowest: compounds 4 and 1 (each within the scatter of the next); then compound 2. At a limit, above all of these: compound 3.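

The place on the saturated chain carbon bound to an aromatic carbon now has its first measured step, a 1.6-fold lower number from compound 1 to compound 4 (0.20 log units; within the scatter), in this assay. With the tert-butoxycarbonyl kept, the group with one five-membered aromatic ring and the sulfur-bearing group with one five-membered non-aromatic ring cannot be told apart in this read-out. Nothing measured here explains this match.

From the compounds shown here alone, whether the same exchange holds with the amide hydrogen in place of tert-butoxycarbonyl remains open. So does what an amine or a carboxylic acid at this place would give.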